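A few compounds are considered here, and "the series" means these few. Any claim that something is new, unique, unknown or untested is made for them only; others in the source may bear on it.

Measured compounds in an in vivo ADME assay on the whole organism (strain Sprague-Dawley) for pharmacokinetics, with Rattus norvegicus as the target; on this read-out higher numbers stand for wider distribution into tissues and lower numbers for narrower distribution:
- compound 1 `Cc1cc(CCC(=O)O)ccc1-c1noc(-c2ccc(OC(C)C)c(C#N)c2)n1`: 0.2 L/kg
- compound 2 `Cc1cc([C@@H]2C[C@H]2C(=O)O)ccc1-c1noc(-c2ccc(OC(C)C)c(C#N)c2)n1`: "not determined" (no result reported); 1 L/kg; 0.4 L/kg (3 entries)

Compound 1 holds the only single number shown in this assay; compound 2 has several entries but no single number, as the record of its repeats shows: the several entries of compound 2 in this assay, "not determined" (no result reported); 1 L/kg; 0.4 L/kg (3 entries). Among the compounds with values here, no two measured compounds differ in one place only, so no measured step exists.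

Compound 3 `Cc1cc([C@H]2C[C@H]2C(=O)O)ccc1-c1noc(-c2ccc(OC(C)C)c(C#N)c2)n1` is not yet measured. It differs from compound 1 in this way: 2-carboxycyclopropyl in place of 2-carboxyethyl on an aromatic carbon. The 2-carboxycyclopropyl group brings two defined stereocentres, and compound 2 carries the same group with the other stereochemistry.

The entries of compound 2 sit at or somewhat above the value of compound 1, so a modest step upward is expected for compound 3, a 2.5-fold higher number from compound 1 to compound 3 (0.40 log units; beyond the scatter), of a size at the edge of the usual scatter rather than clearly beyond it. Compound 3 is estimated at 0.5 L/kg, with a range from 0.2 L/kg to 1.2 L/kg.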

Compound 3, volume of distribution at steady state: 0.7 L/kg
For compound 3 the middle estimate is 1.4-fold (0.15 log units) below the measured one; measured number inside the range.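

Placing 2-carboxycyclopropyl in place of 2-carboxyethyl on an aromatic carbon, para to a large group, gives a 3.5-fold higher number from compound 1 to compound 3 (0.54 log units; beyond the scatter) in this assay and is the first step that can be read at this position. The read-out therefore moves when the chain is closed into a three-membered ring of carbon, while the counts of hydrogen-bond donors and acceptors and the net charge stay the same. Compound 2 differs from compound 3 only in configuration as drawn, and compound 3 at 0.7 L/kg lies inside the span of the entries for its partner: the several entries of compound 2 in this assay, "not determined" (no result reported); 1 L/kg; 0.4 L/kg (3 entries)

Going by these compounds, whether configuration at the cyclopropyl ring changes distribution at all remains open on these few numbers. On these data alone, how a longer chain, or a primary amide in place of the carboxylic acid, would read at this position also remains open.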